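Tert-butyl for 3-methylphenyl on two related cores

A few compounds are considered here, and "the series" means these few. Any claim that something is new, unique, unknown or untested is made for them only; others in the source may bear on it.

Compound 1 `C=C1[C@H](OC(C)=O)[C@@H](OC(=O)C(C)(C)C)[C@@H](OC(C)=O)C(C)(C)/C=C/[C@H](C)[C@H](OC(=O)c2ccccc2)[C@@]2(O)C[C@@](C)(O)[C@H](OC(C)=O)[C@@H]2[C@H]1OCC(C)C` sits at the limit > 100000 nM in a functional assay on MCF7 cells (Homo sapiens) for antiproliferative activity, read by MTT assay, with a stated time of 48 h; on this read-out lower numbers stand for stronger inhibition and higher numbers for weaker inhibition.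
Compound 2 `C=C1[C@H](OC(C)=O)[C@@H](OC(=O)c2cccc(C)c2)[C@@H](OC(C)=O)C(C)(C)/C=C/[C@H](C)[C@H](OC(=O)c2ccccc2)[C@@]2(O)C[C@@](C)(O)[C@H](OC(C)=O)[C@@H]2[C@H]1OCC(C)C` gives 23400 nM in this assay.
Compound 3 `C=C1[C@H](OC(C)=O)[C@@H](OC(=O)c2cccc(C)c2)[C@@H](OC(C)=O)C(C)(C)/C=C/[C@H](C)[C@H]2O[C@]3(C)C[C@@]2(OC(=O)c2ccccc2)[C@H]([C@H]3OC(C)=O)[C@H]1OCC(C)C` sits at the limit > 100000 nM in this assay.

Compound 4 `C=C1[C@H](OC(C)=O)[C@@H](OC(=O)C(C)(C)C)[C@@H](OC(C)=O)C(C)(C)/C=C/[C@H](C)[C@H]2O[C@]3(C)C[C@@]2(OC(=O)c2ccccc2)[C@H]([C@H]3OC(C)=O)[C@H]1OCC(C)C` is not yet measured in this assay.

The pair compound 2 and compound 1 differ by tert-butyl in place of 3-methylphenyl on a carbonyl carbon. The step of an at least 4.2-fold higher number from compound 2 to compound 1 (0.63 log units; beyond the scatter) points to weaker inhibition, and the size of that step is bounded because compound 1 rests on (the limit of > 100000 nM in this assay, at which 2 of the 3 values shown sit). The cores of compound 2 and compound 3 differ in a way that is not broken down here. Compound 3 and compound 4 differ by tert-butyl in place of 3-methylphenyl on a carbonyl carbon, the same change as between compound 2 and compound 1, at the same place.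

Compound 3 already stands at the limit, so the change that lowered activity on the core of compound 2 is expected to leave compound 4 at or beyond that limit. Compound 4 is expected to give 200000 nM in this assay, with a range from 100000 nM to 600000 nM and an expected step that the limit leaves unreadable from compound 3 to compound 4.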

Compound 4, half-maximal inhibitory concentration: > 100000 nM
Compound 4 was reported as a limit; the forecaster's own chance of this, stated with the estimate: 90%; the middle value is on the limit's open side.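

No step can be read from compound 3 to compound 4, because both compounds rest on a limit and not on a number: the limit of > 100000 nM in this assay, at which 3 of the 4 values shown sit.

The compounds shown leave open whether tert-butyl in place of 3-methylphenyl on a carbonyl carbon changes inhibition at all on the core of compound 3.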